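A Hydroxy for a Methyl on the Side Chain

This account rests on a few compounds, and the source may have more. Where it says the series, first, only, none or still open, it means among the compounds named here.

Two compounds have been examined so far. Compound 1 (`COc1ccc(Nc2nc(C#CC(C)(C)C)nc(Nc3ccc(OC)cc3)n2)cc1`) returned > 100000000 nM in a functional assay on C6 cells (Homo sapiens) for cytotoxicity against C6 (Rattus norvegicus), with a stated time of 48 h (a higher number here means a weaker inhibitor, a lower number a stronger inhibitor), as a limit of the assay and not as a number.

Within the data shown here, compound 2 (`COc1nc(C#CC(C)(C)C)nc(OC)n1`) gave 16600 nM in this assay and therefore holds the only actual number so far, with no second number to rank it against.

Compound 3 (`COc1nc(C#CC(C)(C)O)nc(OC)n1`) has not yet been measured. It departs from compound 2 in a single place (hydroxy in place of methyl on a saturated chain carbon bound to two saturated chain carbons and a triple-bonded carbon), with hydroxy in place of methyl on a saturated chain carbon bound to two saturated chain carbons and a triple-bonded carbon. The same difference reads tert-butyl to 1-hydroxy-1-methylethyl.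

Among the measured compounds shown here, no measured pair shows what this change does in this assay, so the expectation starts from compound 2 at 16600 nM and allows for a modest move toward a weaker inhibitor, perhaps not far beyond the usual scatter. The expected step is a 1.8-fold higher number from compound 2 to compound 3 (0.26 log units; within the scatter) and it remains a cautious guess. For compound 3 the estimated value is 30000 nM with an expected range from 9000 nM to 120000 nM in this measurement.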

Compound 3, half-maximal inhibitory concentration: 16200 nM
Beside the measured number, compound 3's estimate is 1.9-fold (0.27 log units) above it; the measured number falls inside the stated range.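

Hydroxy in place of methyl on a saturated chain carbon bound to two saturated chain carbons and a triple-bonded carbon gives a 1.0-fold lower number from compound 2 to compound 3 (0.01 log units; within the scatter) in this assay for this pair. Among these compounds, this is the first measured pair at this position, and it shows that the change from tert-butyl to 1-hydroxy-1-methylethyl, which adds one hydrogen-bond donor and one hydrogen-bond acceptor by the count of the two groups, leaves the number within the scatter. Compound 2 and compound 3 therefore cannot be told apart in this measurement, and nothing in the data shown bears on why the two numbers agree.

The compounds shown leave open whether any single exchange at this carbon moves the number beyond the scatter, as an amine, a carboxylic acid or a longer chain in place of the hydroxy might or might not do. They also leave open what happens in this measurement when one methoxy group on the shared core of compound 2 gives way to a single amine while the tert-butyl stays in place.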